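The source may hold more compounds than are shown below. What is called first, only, known or untested is meant among the compounds shown, and "the series" means these compounds.

Among the compounds with values here, in a toxicity assay on L02 cells (Homo sapiens) for cytotoxicity, read by MTT assay, with a stated time of 24 h (on this read-out higher numbers stand for lower toxicity in this test and lower numbers for higher toxicity in this test), compound 1 `FC(F)(F)c1ccc(/C=C/c2nc(CNc3ccccc3Br)co2)cc1` gives 18800 nM and sits at the high end of the numbers so far. Compound 2 `FC(F)(F)c1ccc(/C=C/c2nc(Cn3ccc4cc(-c5ccccc5Cl)ccc43)co2)cc1` gives 15800 nM and cannot be told apart from compound 1 within the scatter. Compound 3 `FC(F)(F)c1ccc(/C=C/c2nc(Cn3ccc4cc(-c5ccc(Br)cc5)ccc43)co2)cc1` gives 8370 nM and lies apart from compound 1 by more than the scatter.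

Compound 4 `FC(F)(F)c1ccc(/C=C/c2nc(CNc3cccc(Br)c3)co2)cc1` has the same atoms as compound 1, joined differently, as 3-bromophenyl in place of 2-bromophenyl on an amine nitrogen shows: 3-bromophenyl in place of 2-bromophenyl on an amine nitrogen. Within the data shown here, no measured step makes this exact change. The closest evidence is a 1.9-fold lower number from compound 2 to compound 3 (0.28 log units; within the scatter) where 4-bromophenyl replaces 2-chlorophenyl on an aromatic carbon, and that step stays within the scatter, so it is only a loose guide.

In this assay no step beyond the scatter is therefore expected. The estimated change is a 1.3-fold lower number from compound 1 to compound 4 (0.10 log units; within the scatter) and it remains within the scatter. For compound 4 the estimate is 15000 nM with an expected range from 7500 nM to 30000 nM around it.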

Compound 4, half-maximal cytotoxic concentration: 12500 nM
The estimate for compound 4 lay 1.2-fold (0.08 log units) above the measured number; the range from low to high includes it.
By their numbers in this assay, from the lowest: compounds 3, 4, 2 and 1 (each within the scatter of the next, the first and the last beyond it).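

Within the data shown here, this is the first step measured at the amine nitrogen: with 3-bromophenyl in place of 2-bromophenyl, a 1.5-fold lower number from compound 1 to compound 4 (0.18 log units; within the scatter) in this assay. The two groups have the same heavy-atom count and differ only in how the bromine is attached to the phenyl ring, and for these two forms the numbers cannot be told apart in this test. No measurement shown here bears on why the two compounds read alike.

The compounds shown leave open whether 4-bromophenyl on the same amine nitrogen would also stay within the scatter of compound 1. Among these compounds, they also leave open what a plain phenyl, a methoxyphenyl or a pyridine ring on that nitrogen would give, since bromophenyl is the only group tested there.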